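The source may hold more compounds than are shown below. What is called first, only, known or untested is meant among the compounds shown, and "the series" means these compounds.

The series shares one core. Compound 1 `O=C(Nc1cccc(-n2cc(-c3ccncc3)c(-c3ccc(Cl)c(O)c3)n2)c1)Nc1cccc(C(F)(F)F)c1` carries a hydroxy group and a 3-(trifluoromethyl)phenyl urea. Compound 2 `COc1cc(-c2nn(-c3cccc(NC(=O)c4cccc(C(F)(F)F)c4)c3)cc2-c2ccncc2)ccc1Cl` has a methoxy group and an amide, and compound 3 `COc1cc(-c2nn(-c3cccc(NC(=O)Nc4ccc(Cl)c(Cl)c4)c3)cc2-c2ccncc2)ccc1Cl` keeps that methoxy group and bears a (3,4-dichlorophenyl)amino group on the carbonyl carbon.

In a functional assay on K562 cells (Homo sapiens) for inhibition, read by sulforhodamine B assay, with a stated time of 48 h (on this read-out lower numbers stand for higher toxicity in this test and higher numbers for lower toxicity in this test), compound 1 gives > 32500 nM, which is a limit of the test and not a number. In this assay compound 2 also reaches only a limit, > 50000 nM. Compound 3 likewise stands at a limit in this assay, > 50000 nM. The step that the two limits leave unreadable from compound 2 to compound 3 therefore cannot be sized. Among the measured compounds shown here, all three compounds sit at limits, one at the limit of > 32500 nM in this assay, at which 1 of the 3 values shown sits, and two at the limit of > 50000 nM in this assay, at which 2 of the 3 values shown sit, so no measured step gives a readable size.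

Compound 4 `O=C(Nc1cccc(-n2cc(-c3ccncc3)c(-c3ccc(Cl)c(O)c3)n2)c1)Nc1ccc(Cl)c(Cl)c1` differs from compound 3 by hydrogen in place of methyl on an oxygen on an aromatic ring: methoxy to hydroxy, 4-chloro-3-methoxyphenyl to 4-chloro-3-hydroxyphenyl. For the measured compounds named here, no measured step bears directly on this change. Since compound 1, which already carries the hydroxy group, gives > 32500 nM, compound 4 is expected to stay at a limit as well. The expected step of a number no higher from compound 3 to compound 4 (the limit leaves the size open) is none beyond the scatter. Compound 4 is estimated at 50000 nM, with a range from 20000 nM to 100000 nM.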

Compound 4, concentration lethal to 50% of the cells: > 32500 nM
Compound 4: only a limit was reported; the forecaster's own chance of this, stated with the estimate: 85%; the middle value does not contradict the limit.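

In this assay compound 4 gives > 32500 nM, which is a limit of the test and not a number. The steps to compound 4 from compound 3 and from compound 1 therefore cannot be read. The compounds shown leave open whether any of these changes alters toxicity in this assay, and at what concentration any of the four compounds would reach it.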